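Chain length on the sulfonamide nitrogen of the aryl group

This account rests on a few compounds, and the source may have more. Where it says the series, first, only, none or still open, it means among the compounds named here.

Measured compounds in an assay for binding affinity to dual specificity mitogen-activated protein kinase kinase 4 (Homo sapiens), read by KINOMEscan, tested at 10 nM; a lower number here means a stronger effect, a higher number a weaker effect of the compound at the concentration tested:
compound 1 `CCCS(=O)(=O)Nc1ccc(F)c(C(=O)c2n[nH]c3ncc(-c4ccc(N)cc4)cc23)c1F` gives 3.7%
compound 2 `CCCS(=O)(=O)Nc1ccc(F)c(C(=O)c2n[nH]c3ncc(-c4ccc(S(N)(=O)=O)cc4)cc23)c1F` gives 5.1%
compound 3 `CCCS(=O)(=O)Nc1ccc(F)c(C(=O)c2n[nH]c3ncc(-c4ccc(S(=O)(=O)NC)cc4)cc23)c1F` gives 14%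

Compound 3 has the highest of the three numbers in this assay. Its nearest neighbour is compound 2, and that step, a number 8.9 percentage points higher from compound 2 to compound 3 (within the scatter), lies within the scatter, so the two are not ordered. The step from the amino compound, a number 10.3 percentage points higher from compound 1 to compound 3 (beyond the scatter), is beyond the scatter but modest. The other pair, a number 1.4 percentage points higher from compound 1 to compound 2 (within the scatter), also stays within the scatter.

Compound 4 `CCCS(=O)(=O)Nc1ccc(F)c(C(=O)c2n[nH]c3ncc(-c4ccc(S(=O)(=O)NCC)cc4)cc23)c1F` is not yet measured. It differs from compound 3 by methyl in place of hydrogen on a saturated chain carbon bound to a sulfonamide nitrogen.

Among the compounds with values here, the one measured step at the same sulfonamide nitrogen is the methyl for hydrogen change, a number 8.9 percentage points higher from compound 2 to compound 3 (within the scatter), which did not exceed the scatter. Lengthening methyl to ethyl is a further small change at that position, and nothing among the three compounds speaks for a large shift in either direction. The expectation for compound 4 in this assay is therefore a small rise at most, a number 4 percentage points higher from compound 3 to compound 4 (within the scatter), likely within the scatter.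

Compound 4 is estimated at 18%, with a range from 8% to 35%.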

Compound 4, a percentage reported as activity, at one concentration (the size of the read-out at that concentration, not a potency): 41%
The estimate for compound 4 lay 23 percentage points below the measured number; measured number outside the range, above it.
By their numbers in this assay, from the lowest: compounds 1, 2 and 3 (each within the scatter of the next, the first and the last beyond it); then compound 4.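

In this assay, chain length on the sulfonamide nitrogen now has a clear effect: going from methyl to ethyl gives a number 27 percentage points higher from compound 3 to compound 4 (beyond the scatter), whereas hydrogen to methyl gave a number 8.9 percentage points higher from compound 2 to compound 3 (within the scatter). Within the data shown here, the ethyl group also separates this compound from the unsubstituted sulfamoyl, with a number 35.9 percentage points higher from compound 2 to compound 4 (beyond the scatter), and ethylsulfamoyl in place of amino gives a number 37.3 percentage points higher from compound 1 to compound 4 (beyond the scatter), so all three steps to compound 4 lie beyond the scatter and the methyl group added on the saturated chain carbon is enough to set compound 4 apart from the earlier compounds. No available evidence bears on the reason for this jump.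

Open, going by these compounds, is whether the number keeps rising with a longer chain such as propyl or butyl, or whether a branched isopropyl, a cyclopropyl or a dimethylsulfamoyl group reads like ethyl. Also open, on these data alone, is whether a hydroxyl or an amine at the end of the ethyl chain would bring the number back towards those of the sulfamoyl and methylsulfamoyl compounds.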